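This account rests on a few compounds, and the source may have more. Where it says the series, first, only, none or still open, it means among the compounds named here.

Measured in a functional assay on 518A2 cells (Homo sapiens) for cytotoxicity, read by MTT assay, with a stated time of 72 h; on this read-out lower numbers stand for stronger inhibition and higher numbers for weaker inhibition:
- compound 1 `CN1C/C(=C\c2c(F)cc(F)cc2F)C(=O)/C(=C/c2c(F)cc(F)cc2F)C1`: > 10000 nM (a limit of the assay, not a number)
- compound 2 `CCN1C/C(=C\c2ccc(F)cc2F)C(=O)/C(=C/c2ccc(F)cc2F)C1`: 2400 nM
- compound 3 `CCN1C/C(=C\c2cc(F)cc(F)c2)C(=O)/C(=C/c2cc(F)cc(F)c2)C1`: 3300 nM

Compound 1 stands at the limit of > 10000 nM in this assay, at which 1 of the 3 values shown sits. That entry is a limit, so the true position of compound 1 in this assay is not known as a number.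

Compound 4 `CCN1C/C(=C\c2c(F)cc(F)cc2F)C(=O)/C(=C/c2c(F)cc(F)cc2F)C1` has not yet been measured. It differs from compound 1 in one place: methyl in place of hydrogen on a saturated chain carbon bound to an amine nitrogen in a ring. In words, this is methyl in place of hydrogen on a saturated chain carbon bound to an amine nitrogen in a ring, which turns a methyl into an ethyl.

Going by the values given here, no measured pair shows this change on its own, so any expectation is indirect. The ethyl group is also present in two compounds that differ from compound 4 in their fluorine substitution. These give numbers rather than a limit, with compound 2 at 2400 nM and compound 3 at 3300 nM. On that basis, a shift toward stronger inhibition is expected, although compound 4 could still reach the limit. The expected step, an estimate only, is an at least 2.0-fold lower number from compound 1 to compound 4 (0.30 log units; that floor lies within the scatter). For compound 4 the estimated value is 5000 nM, with an expected range from 1800 nM to 14000 nM.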

Compound 4, half-maximal inhibitory concentration: 2000 nM
Beside the measured number, compound 4's estimate is 2.5-fold (0.40 log units) above it, within the range that was stated.
By their numbers in this assay, from the lowest: compounds 4, 2 and 3 (each within the scatter of the next). At a limit, above all of these: compound 1.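

In this assay, this pair is the only direct view of this position with the fluorine pattern held fixed, and turning the methyl into an ethyl gives an at least 5.0-fold lower number from compound 1 to compound 4 (0.69 log units; beyond the scatter). The earlier compounds shown here could not show this: compound 2 and compound 3 also carry the ethyl, but they differ from compound 4 in their fluorine substitution, so they say nothing about the methyl and the ethyl on a shared pattern. The pair shows that this small change at this place is enough to move the compound from the limit of the assay to a measurable number, but the printed step is only a floor, because compound 1 has a limit, not a number: the limit of > 10000 nM in this assay, at which 1 of the 4 values shown sits.

Going by these compounds alone, the true size of the step remains unknown, and with only one pair showing the change, it is open whether the same change would lower the number on other fluorine patterns. Also open, on these data alone, is how the series would read with a longer chain such as propyl at this place, or with a chain ending in an amine or a carboxylic acid, and the data give no reason for the shift.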